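A few compounds are considered here, and "the series" means these few. Any claim that something is new, unique, unknown or untested is made for them only; others in the source may bear on it.

Measured compounds:
- compound 1 `COc1cc(-c2nnc3n2NC(c2ccco2)C(C(=O)c2ccccc2C)S3)cc(OC)c1OC`: 88400 nM
- compound 2 `COc1cc(-c2nnc3n2NC(c2ccco2)C(C(=O)c2ccc(C)cc2)S3)cc(OC)c1OC`: 7500 nM
- compound 3 `COc1cc(-c2nnc3n2NC(c2ccco2)C(C(=O)c2ccc(O)cc2)S3)cc(OC)c1OC`: 38300 nM

In a functional assay on PC-3 cells (Homo sapiens) for cytotoxicity, read by MTT assay, with a stated time of 48 h (on this read-out higher numbers stand for weaker inhibition and lower numbers for stronger inhibition), compound 1 gives the highest of the three numbers. Compound 2 lies furthest from it, a step described as a 12-fold lower number from compound 1 to compound 2 (1.07 log units; beyond the scatter), and compound 3 lies nearest, with a 2.3-fold lower number from compound 1 to compound 3 (0.36 log units; beyond the scatter). Between these two, compound 2 and compound 3 are separated by a 5.1-fold higher number from compound 2 to compound 3 (0.71 log units; beyond the scatter).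

Compound 4 `COc1cc(-c2nnc3n2NC(c2ccco2)C(C(=O)c2cccc(Br)c2)S3)cc(OC)c1OC` differs from compound 1 in one place: 3-bromophenyl in place of 2-methylphenyl on a carbonyl carbon. Both measured steps that leave compound 1 replace the 2-methylphenyl with another phenyl group on the carbonyl carbon, and both give lower numbers in this assay, one large and one modest. Neither of them puts a bromine on that ring, so the direction is better supported than the size. A lower number is therefore expected for compound 4, most likely of modest size, a 3.5-fold lower number from compound 1 to compound 4 (0.55 log units; beyond the scatter). The estimate for compound 4 in this assay is 25000 nM, within a range from 7000 nM to 90000 nM.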

Compound 4, half-maximal inhibitory concentration: 63900 nM
Compound 4: middle estimate off by 2.6-fold (0.41 log units), on the low side, and the stated range covers the measured number.
By their numbers in this assay, from the lowest: compound 2; then compounds 3, 4 and 1 (each within the scatter of the next, the first and the last beyond it).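

In this assay, the 3-bromophenyl group on the carbonyl carbon does not bring the clear drop that the earlier replacements of 2-methylphenyl suggested: a 1.4-fold lower number from compound 1 to compound 4 (0.14 log units; within the scatter), and a 1.7-fold higher number from compound 3 to compound 4 (0.22 log units; within the scatter). Changing the aryl group on the carbonyl carbon therefore does not in itself lower the number, and among the four compounds only the 4-methylphenyl group of compound 2 stands apart, with an 8.5-fold higher number from compound 2 to compound 4 (0.93 log units; beyond the scatter). Nothing available here explains why that group stands apart.

The compounds shown leave open whether the result for compound 2 follows from the methyl group or from where it sits on the ring, a question that 3-methylphenyl and 4-bromophenyl groups would separate. As far as these compounds go, it also remains open whether a 4-aminophenyl group or a 4-carboxyphenyl group on the carbonyl carbon would read like compound 2 or like compound 4.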